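Aortic relaxation series: cyanophenyl urea position swap

The source may report more compounds than this note shows. Statements on the series, on what has been measured and on what is new or still open speak of the compounds shown alone.

Compound 1 `CC1(C)CC(NC(=O)Nc2ccc(C#N)cc2)c2cc(NS(C)(=O)=O)ccc2O1`: 19800 nM
Compound 2 `CCS(=O)(=O)Nc1ccc2c(c1)C(NC(=O)Nc1cccc(C#N)c1)CC(C)(C)O2`: 9500 nM

Of the compounds shown here, two have been measured in a functional assay on thoracic aorta (Rattus norvegicus) for inhibition; a higher number here means that more compound is needed for the effect, a lower number that less compound is needed. Compound 2 gives 9500 nM, the lower of the two numbers; its nearest neighbour is compound 1, which gives 19800 nM, a gap beyond the scatter. Within the data shown here, no pair differing in a single place has been measured, so no step size is established.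

Compound 3 `CCS(=O)(=O)Nc1ccc2c(c1)C(NC(=O)Nc1ccc(C#N)cc1)CC(C)(C)O2` differs from compound 2 by 4-cyanophenyl in place of 3-cyanophenyl on an amide-type nitrogen. Compound 1 also carries the 4-cyanophenyl group, yet differs from compound 3 elsewhere, so it only hints at the direction. A modest move toward a higher number is expected for the step from compound 2 to compound 3, a 1.6-fold higher number from compound 2 to compound 3 (0.20 log units; within the scatter), and it may not exceed the scatter. Compound 3 is estimated at 15000 nM, within 5000 nM to 45000 nM.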

Compound 3, half-maximal effective concentration: 11800 nM
Estimate against measurement, compound 3: 1.3-fold (0.10 log units) above, and the stated range covers the measured number.
By their numbers in this assay, from the lowest: compounds 2, 3 and 1 (each within the scatter of the next, the first and the last beyond it).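

In this assay, 4-cyanophenyl in place of 3-cyanophenyl on the amide-type nitrogen gives a 1.2-fold higher number from compound 2 to compound 3 (0.09 log units; within the scatter), so this swap of the nitrile-bearing group has no resolved effect on the number. Among these compounds, the first single-place reading on the sulfonyl side, methyl in place of hydrogen on the saturated chain carbon bound to the sulfonyl sulfur, gives a 1.7-fold lower number from compound 1 to compound 3 (0.22 log units; within the scatter), and this step also stays inside the scatter. Nothing on hand speaks to the mechanism behind either step.

As far as these compounds go, whether a carboxylic acid or an amine in place of the nitrile, or a chain longer than ethyl on the sulfonyl sulfur, would move the number beyond the scatter remains open. Also open, from the compounds shown here alone, is whether the two steps add up when both changes are combined.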